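Working notes: the step from compound 3 to compound 4

The source may hold more compounds than are shown below. What is called first, only, known or untested is meant among the compounds shown, and "the series" means these compounds.

Measured in a functional assay on K562 cells (Homo sapiens) for cytotoxicity, read by MTT assay, with a stated time of 72 h; on this read-out higher numbers stand for weaker inhibition and lower numbers for stronger inhibition:
- compound 1 `CC(C)(C)C1=CC(=O)C=C(NCCC(=O)O)C1=O`: 67000 nM
- compound 2 `CC1=CCC[C@H]2[C@](C)(CC3=CC(=O)C(N4CCC[C@H]4C(=O)O)=CC3=O)[C@@H](C)CC[C@]12C`: 35400 nM
- compound 3 `CSCC[C@H](NC1=CC(=O)C=C(C[C@]2(C)[C@@H](C)CC[C@]3(C)C(C)=CCC[C@@H]23)C1=O)C(=O)O`: 13600 nM

Compound 3 at 13600 nM gives the lowest number of the three, and both compound 2 and compound 1 lie above it beyond the scatter. Compound 4 `CC1=CCC[C@H]2[C@](C)(CC3=CC(=O)C=C(N[C@@H](C)C(=O)O)C3=O)[C@@H](C)CC[C@]12C` is not yet measured. It differs from compound 3 by hydrogen in place of (methylsulfanyl)methyl on a saturated chain carbon, two bonds along the chain from an amine nitrogen and a carbonyl carbon. Within the data shown here, no pair of measured compounds differs in one place only, so the series gives no direct measure of this change. Compound 2 also lacks the (methylsulfanyl)methyl group and gives 35400 nM, so a modest move toward a higher number seems likely in this assay. The expected change is a 1.8-fold higher number from compound 3 to compound 4 (0.25 log units; within the scatter), close to the edge of the scatter. For compound 4 the estimated value is 24000 nM, with an expected range of 10000 nM to 60000 nM.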

Compound 4, half-maximal inhibitory concentration: 15800 nM
Compound 4: middle estimate off by 1.5-fold (0.18 log units), on the high side; low and high end bracket the measured number.
By their numbers in this assay, from the lowest: compounds 3 and 4 (each within the scatter of the next); then compounds 2 and 1 (each within the scatter of the next).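

In this assay, among these compounds, the change a 1.2-fold higher number from compound 3 to compound 4 (0.07 log units; within the scatter) gives the first direct reading at this position, and that step lies within the scatter. On a saturated chain carbon, two bonds along the chain from an amine nitrogen and a carbonyl carbon, the (methylsulfanyl)methyl group is therefore not required to keep the number at the level of compound 3. Nothing available gives a reason for this result.

Hydrogen and (methylsulfanyl)methyl are the only two groups compared here in a one-place step, so it remains open whether a phenyl ring, an amine or a second carboxylic acid on this carbon would move the number beyond the scatter. Compound 1 and compound 2 differ from compound 4 in more than one place, which leaves the effect of each of their other changes unresolved.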